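The source may hold more compounds than are shown below. What is called first, only, known or untested is meant among the compounds shown, and "the series" means these compounds.

The measured compounds:

compound 1, `N#Cc1ccc(Cn2cncc2CN(C(=O)c2ccccc2)c2ccc(N3CCN(C(=O)c4ccc(Cl)s4)CC3)cc2)cc1`, in a functional assay on DLD-1 cells (Homo sapiens) (a higher number here means a weaker inhibitor, a lower number a stronger inhibitor), compound 1 gives 3 nM.
compound 2, `N#Cc1ccc(Cn2cncc2CN(C(=O)c2cccc(Cl)c2)c2ccc(N3CCN(C(=O)c4ccc(Cl)s4)CC3)cc2)cc1`, in this assay compound 2 gives 2 nM.

Compound 2 stands next to compound 1 on these numbers, and the two values sit within the usual scatter of each other: the step of a 1.5-fold lower number from compound 1 to compound 2 (0.18 log units; within the scatter) carries no weight on its own. Within the data shown here, that single step, chloro in place of hydrogen on an aromatic carbon, is the only measured comparison in this set.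

Compound 3, `COc1ccccc1C(=O)N(Cc1cncn1Cc1ccc(C#N)cc1)c1ccc(N2CCN(C(=O)c3ccc(Cl)s3)CC2)cc1`, is not yet measured. It differs from compound 2 in one place: 2-methoxyphenyl in place of 3-chlorophenyl on a carbonyl carbon. The step from compound 1 to compound 2 touches the same aromatic ring, but it swapped a hydrogen for a chlorine and left the ring otherwise unchanged; it does not speak to a methoxy group entering as the chlorine leaves. Among the measured compounds shown here, with only one step to go on, and that one within the scatter, there is no basis for expecting a change beyond the scatter in this assay. Compound 3 is therefore estimated at 4 nM, with a range of 1.5 nM to 12 nM. The expected step of a 2.0-fold higher number from compound 2 to compound 3 (0.30 log units; within the scatter) is thus one that the scatter would cover.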

Compound 3, half-maximal inhibitory concentration: > 10000 nM
Compound 3 ended at the assay's limit; the forecaster's own chance of this, stated with the estimate: 2%; middle value at least 2500-fold (3.39 log units) from the limit.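

Up to this point the aromatic ring on this carbonyl carbon had only shown a change that carried no weight, a 1.5-fold lower number from compound 1 to compound 2 (0.18 log units; within the scatter), which is within the scatter. With 2-methoxyphenyl on the same carbonyl carbon, the picture in this assay is very different, with an at least 5000-fold higher number from compound 2 to compound 3 (3.69 log units; beyond the scatter), so this place does not accept every substituted phenyl ring. The comparison with the unsubstituted ring gives an at least 3300-fold higher number from compound 1 to compound 3 (3.52 log units; beyond the scatter), so the large loss does not depend on the chlorine leaving: it also appears when methoxy simply takes the place of a hydrogen.

Compound 3 stands at > 10000 nM, which is a limit of the assay and not a number, so both large steps give only a minimum size: the limit of > 10000 nM in this assay, at which 1 of the 3 values shown sits.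

On these data alone, what stays open is whether the loss follows the methoxy group itself or its place on the ring, as 2-methoxyphenyl and 3-chlorophenyl differ in both the group and its place. As far as these compounds go, it also remains open how a hydroxy group, a methyl group or an amine would fare on this ring.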